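A few compounds are considered here, and "the series" means these few. Any claim that something is new, unique, unknown or untested is made for them only; others in the source may bear on it.

Compound 1 `CC1=CCCC(C)(C)C1/C=C/C(=O)/C=C/c1cccc(C(F)(F)F)c1`: 5200 nM
Compound 2 `CC1=CCCC(C)(C)C1/C=C/C(=O)/C=C/c1ccc(C(F)(F)F)cc1`: 7900 nM
Compound 3 `CC1=CCCC(C)(C)C1/C=C/C(=O)/C=C/c1cc(C(F)(F)F)ccc1F`: 3100 nM

Of the compounds shown here, three sharing one core have been measured in a functional assay on PC-3 cells (Homo sapiens) for cytotoxicity, read by MTT assay, with a stated time of 72 h; on this read-out lower numbers stand for stronger inhibition and higher numbers for weaker inhibition. Compound 1 gives 5200 nM and stands second highest of the three numbers. Compound 2 gives 7900 nM, and the two values lie within the scatter of each other, so nothing separates them. For the measured compounds named here, the one step that joins two measured compounds by a single change is the fluoro added on an aromatic carbon, which gives a 1.7-fold lower number from compound 1 to compound 3 (0.22 log units; within the scatter), a move that also stays within the scatter.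

Compound 4 `CC1=CCCC(C)(C)C1/C=C/C(=O)/C=C/c1cccc([N+](=O)[O-])c1` differs from compound 1 in one place: nitro in place of trifluoromethyl on an aromatic carbon. Going by the values given here, no measured step exchanges one group for another on the aromatic ring, so none bears directly on this change. Among the compounds with values here, the only step that touches the ring at all, a 1.7-fold lower number from compound 1 to compound 3 (0.22 log units; within the scatter), shows a small move, and the three numbers as a whole stay close together. On that basis compound 4 is expected to sit near compound 1, with a step of a 1.2-fold lower number from compound 1 to compound 4 (0.06 log units; within the scatter), which is not beyond the scatter. The estimate for compound 4 in this assay is 4500 nM, with a range from 1500 nM to 13000 nM.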

Compound 4, half-maximal inhibitory concentration: 2900 nM
Estimate against measurement, compound 4: 1.6-fold (0.19 log units) above; the range from low to high includes it.
By their numbers in this assay, from the lowest: compounds 4, 3, 1 and 2 (each within the scatter of the next, the first and the last beyond it).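

In this assay, the exchange of trifluoromethyl for nitro on an aromatic carbon, meta to a large group, gives a 1.8-fold lower number from compound 1 to compound 4 (0.25 log units; within the scatter). This is the first step among the compounds shown that replaces one group on the ring with another rather than adding a fluoro, and it shows that a group with different atoms, and with hydrogen-bond acceptors where trifluoromethyl has none, can stand at this position without a change that rises above the scatter, so that the two groups cannot be told apart on these numbers. No measurement among the data shown offers an explanation for this result.

What the compounds shown leave open is whether this position would keep its values within the same narrow span with a group of another kind on the same aromatic carbon, such as an amine, a carboxylic acid or a nitrile. From the compounds shown here alone, it also remains open whether nitro would behave as trifluoromethyl does when a fluoro is added to the ring.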